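The source may hold more compounds than are shown below. What is called first, only, known or untested is meant among the compounds shown, and "the series" means these compounds.

Of the compounds shown here, two have been measured in a functional assay on HCT-116 cells (Homo sapiens) for antiproliferative activity, read by MTT assay, with a stated time of 72 h; on this read-out lower numbers stand for stronger inhibition and higher numbers for weaker inhibition. Compound 1 `NC1=NC2(CCSCC2)N(OCCCOc2ccc(Br)cc2)C(N)=N1` gives 20 nM in this assay. Compound 2 `NC1=NC2(CCOCC2)N(OCCCOc2ccc(F)cc2)C(N)=N1` gives 3280 nM in this assay, the highest number of the two and so the weaker of the pair; compound 1 differs from it in two places at once, so their two values show only that a wide gap separates them. Compound 3 `NC1=NC2(CCOCC2)N(OCCCOc2ccc(Br)cc2)C(N)=N1` has not yet been measured in this assay. Compared with compound 2, the change is bromo in place of fluoro on an aromatic carbon. Within the data shown here, the 4-bromophenoxy group that results is the one carried by compound 1. Because compound 1 gives 20 nM, a lower number is expected for compound 3, though the shared core of compound 1 is not that of compound 3, so only part of the gap is expected to close. The expected step of an 8.2-fold lower number from compound 2 to compound 3 (0.91 log units; beyond the scatter) is therefore downward and beyond the scatter. Compound 3 is estimated at 400 nM, with a range from 50 nM to 2500 nM.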

Compound 3, half-maximal inhibitory concentration: 320 nM
For compound 3 the middle estimate is 1.3-fold (0.10 log units) above the measured one; the measured number falls inside the stated range.
By their numbers in this assay, from the lowest: compound 1; then compound 3; then compound 2.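

In this assay replacing the fluoro of the 4-fluorophenoxy group with bromo, with nothing else altered, gives a 10-fold lower number from compound 2 to compound 3 (1.01 log units; beyond the scatter) in a single change. Among these compounds, the two earlier compounds differed in two places at once, so this is the first sign that this one atom on the aromatic ring matters by itself. With bromo in place, compound 3 at 320 nM and compound 1 at 20 nM still stand apart, so this change alone does not span the whole gap between compound 2 and compound 1.

Going by these compounds, whether chloro, iodo or a methoxy group on the same ring carbon would give a lower or higher number remains open, as does the size of the same change on the core of compound 1. Nothing measured here explains why bromo gives the lower number.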